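Acetyl for Trifluoromethyl on a Shared Core

The source may hold more compounds than are shown below. What is called first, only, known or untested is meant among the compounds shown, and "the series" means these compounds.

Measured so far:
compound 1, `Cc1cccc2nc(N3CCN(C)CC3)oc12`: 5.48
compound 2, `CN1CCN(c2nc3cc(C(F)(F)F)ccc3o2)CC1`: < 4

In a functional assay on ileum (strain Hartley) for agonist activity at 5-hydroxytryptamine receptor 3A (Cavia porcellus) (a lower number here means a less potent compound, a higher number a more potent compound, by a factor of ten per unit of this negative logarithm), compound 1 gives 5.48. Compound 2 is reported only as a limit of this assay, namely < 4, so where compound 2 truly stands is not known, only that it is not above that boundary. This boundary is the limit of < 4 in this assay, at which 1 of the 2 values shown sits. The two compounds also differ in more than one place, so the two values say nothing about any single change.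

The next compound, compound 3, is `CC(=O)c1ccc2oc(N3CCN(C)CC3)nc2c1`. It departs from compound 2 by a single change: acetyl in place of trifluoromethyl on an aromatic carbon. Going by the values given here, no measured pair shows this change, so its effect in this assay is an open question. Since compound 2 stands at a limit, a step from it in this assay can only be upward or within the scatter, and a moderate rise is expected here. Compound 3 is therefore expected to give about 4.4, within 3.7 to 5.1. The expected step from compound 2 to compound 3 is a number at least 0.40 log units higher from compound 2 to compound 3 (beyond the scatter).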

Compound 3, negative logarithm of the half-maximal effective concentration: < 4
Compound 3: no number, only a limit (the forecaster's own chance of this, stated with the estimate: 35%); middle value at least 0.40 log units from the limit.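

In this assay compound 3 is reported only as a limit, < 4. Compound 2 is also reported only as a limit, so the swap of trifluoromethyl for acetyl between compound 2 and compound 3 gives no readable step: the limit of < 4 in this assay, at which 2 of the 3 values shown sit.

The compounds shown leave open where compound 2 and compound 3 truly stand, and whether acetyl and trifluoromethyl differ at all in this assay.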